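This account rests on a few compounds, and the source may have more. Where it says the series, first, only, none or still open, it means among the compounds named here.

Three compounds share one core and differ only in the group attached to the amide-type nitrogen. Compound 1 `Cc1nc(N)sc1CCCN/C(N)=N/C(=O)N[C@@H](C)c1ccccc1` carries a 1-phenylethyl group, and in an assay on membranes from Sf9 cells for displacement of a labelled ligand from histamine H2 receptor (Homo sapiens), read by scintillation counting, with a stated time of 60 min (on this read-out lower numbers stand for stronger inhibition and higher numbers for weaker inhibition), compound 1 gives 51.3 nM. Compound 2 `Cc1nc(N)sc1CCCN/C(N)=N/C(=O)NC(C)c1cccs1` carries a 1-(thiophen-2-yl)ethyl group; in this assay compound 2 gives 63.1 nM, the highest number of the three, although the step of a 1.2-fold higher number from compound 1 to compound 2 (0.09 log units; within the scatter) lies within the scatter of repeated measurements. Compound 3 `Cc1nc(N)sc1CCCN/C(N)=N/C(=O)NCc1ccco1` carries a (furan-2-yl)methyl group, and in this assay compound 3 gives 10.5 nM; the steps of a 4.9-fold lower number from compound 1 to compound 3 (0.69 log units; beyond the scatter) and a 6.0-fold lower number from compound 2 to compound 3 (0.78 log units; beyond the scatter) are the only ones beyond the scatter.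

Compound 4 `Cc1nc(N)sc1CCCN/C(N)=N/C(=O)NC(C)c1ccc(F)cc1` has not yet been measured. It differs from compound 2 in one place: 4-fluorophenyl in place of thiophen-2-yl on a saturated chain carbon bound to an amide-type nitrogen and a saturated chain carbon. Within the data shown here, the one measured step that bears on this change is a 1.2-fold higher number from compound 1 to compound 2 (0.09 log units; within the scatter), where exchanging 1-phenylethyl for 1-(thiophen-2-yl)ethyl on the same carbon changed nothing beyond the scatter; moving back to a six-membered aromatic ring of carbon only is therefore expected to change little as well. Among the measured compounds shown here, no measured compound carries a fluorine, so that part of the change is untested. Compound 4 is expected to give about 55 nM, with a likely range from 25 nM to 120 nM. This estimate means a step of a 1.1-fold lower number from compound 2 to compound 4 (0.06 log units; within the scatter), expected to stay within the scatter.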

Compound 4, inhibition constant: 31.6 nM
Estimate against measurement, compound 4: 1.7-fold (0.24 log units) above; measured number inside the range.
By their numbers in this assay, from the lowest: compound 3; then compounds 4, 1 and 2 (each within the scatter of the next).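

In this assay, the step of a 2.0-fold lower number from compound 2 to compound 4 (0.30 log units; within the scatter) lies within the scatter, so this position accepts 4-fluorophenyl in place of thiophen-2-yl without a change that can be separated from the variation between repeated measurements. Among these compounds, compound 4 is the first compound here to carry a fluorine, and it shows that a ring bearing this atom can sit on the saturated chain carbon without a shift beyond the scatter, a point the earlier compounds could not address. No independent measurement accompanies these numbers that could explain this result.

The separate contribution of the fluorine stays unresolved, since compound 1 has a defined spatial arrangement at the chain carbon and compound 4 has none shown, so that pair differs in more than one place. On these data alone, it also remains open how this position would respond to a chlorine, a methoxy group or an amine on the phenyl ring, or to an ethyl group in place of the methyl on the chain carbon.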